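Swapping 4-aminophenyl for thiophen-3-yl on a carbonyl carbon

The source may report more compounds than this note shows. Statements on the series, on what has been measured and on what is new or still open speak of the compounds shown alone.

Of the compounds shown here, three sharing one core have been measured in a functional assay on NCI-H1299 cells (Homo sapiens) for antiproliferative activity, read by XTT assay, with a stated time of 72 h; a higher number here means a weaker inhibitor, a lower number a stronger inhibitor. Compound 1 (`COc1ccc(-c2cc3ccccc3nc2/C=C/C(=O)c2ccc(F)cc2)cc1`) gives 820 nM, compound 2 (`COc1ccc(-c2cc3ccccc3nc2/C=C/C(=O)c2ccc(OC)cc2OC)cc1`) gives 3770 nM, and compound 3 (`COc1ccc(-c2cc3ccccc3nc2/C=C/C(=O)c2ccc(N)cc2)cc1`) gives 6510 nM. Compound 3 sits with compound 2 at the weak end of this small set: a 1.7-fold higher number from compound 2 to compound 3 (0.24 log units; within the scatter) lies within the scatter, while a 7.9-fold higher number from compound 1 to compound 3 (0.90 log units; beyond the scatter) lies beyond it.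

Compound 4 (`COc1ccc(-c2cc3ccccc3nc2/C=C/C(=O)c2ccsc2)cc1`) carries thiophen-3-yl in place of 4-aminophenyl on a carbonyl carbon. For the measured compounds named here, no measured compound holds thiophen-3-yl, so the evidence is indirect. Changing the group on the carbonyl carbon has so far given a 4.6-fold higher number from compound 1 to compound 2 (0.66 log units; beyond the scatter) as well as the modest step to compound 3 already noted, which shows that this position can move the number beyond the scatter. A modest step towards a lower number is therefore expected in this assay, though its direction is uncertain. The expected change is a 3.6-fold lower number from compound 3 to compound 4 (0.56 log units; beyond the scatter). Compound 4 is estimated at 1800 nM, with an expected range from 600 nM to 5000 nM.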

Compound 4, half-maximal inhibitory concentration: 1220 nM
Estimate against measurement, compound 4: 1.5-fold (0.17 log units) above; measured number inside the range.
By their numbers in this assay, from the lowest: compounds 1 and 4 (each within the scatter of the next); then compounds 2 and 3 (each within the scatter of the next).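

In this assay, for the compounds shown here, the carbonyl carbon now also carries a five-membered aromatic ring with one hetero atom, where the earlier compounds all held a six-membered aromatic ring of carbon only. Thiophen-3-yl moves the number clearly away from both the 4-aminophenyl and the 2,4-dimethoxyphenyl compounds (a 5.3-fold lower number from compound 3 to compound 4 (0.73 log units; beyond the scatter); a 3.1-fold lower number from compound 2 to compound 4 (0.49 log units; beyond the scatter)), while the comparison with the 4-fluorophenyl compound stays within the scatter (a 1.5-fold higher number from compound 1 to compound 4 (0.17 log units; within the scatter)). So a six-membered aromatic ring of carbon only is not required at this position for a number in the range of compound 1, and no measurement on hand explains these steps.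

The compounds shown leave open how thiophen-2-yl, furan-3-yl or a pyridinyl ring would compare on this carbonyl carbon. They also leave open how a simple phenyl or 4-chlorophenyl group would compare with 4-fluorophenyl there.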